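This account rests on a few compounds, and the source may have more. Where it says the series, first, only, none or still open, it means among the compounds named here.

In a functional assay on the whole organism (strain albino) with Mus musculus as the target, in the maximal electroshock model, with a stated time of 0.5 h (a lower number here means that less compound is needed, a higher number that more compound is needed for the effect), compound 1 `Brc1ccc(-c2csc(Nc3nnc(Nc4ccccc4)s3)n2)cc1` gives 300 mg/kg. Compound 2 `Cc1ccc(Nc2nnc(Nc3nc(-c4ccc([N+](=O)[O-])cc4)cs3)s2)cc1` gives 30 mg/kg, and compound 3 `COc1ccccc1Nc1nnc(Nc2nc(-c3ccc([N+](=O)[O-])cc3)cs2)s1` gives 300 mg/kg. Compound 3 therefore stands level with compound 1 at the digits shown, the two together at the top of the three numbers, and it sits a 10-fold higher number from compound 2 to compound 3 (1.00 log units; beyond the scatter).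

Compound 4 `O=[N+]([O-])c1ccc(-c2csc(Nc3nnc(Nc4ccccc4)s3)n2)cc1` differs from compound 3 by one change: hydrogen in place of methoxy on an aromatic carbon. Within the data shown here, no measured pair shows this exact change. Among the measured compounds shown here, the one step that bears on it, the replacement of 4-methylphenyl by 2-methoxyphenyl, a 10-fold higher number from compound 2 to compound 3 (1.00 log units; beyond the scatter), shows that the substitution on that ring can move the number beyond the scatter in this assay. Compound 1, which also carries an anilino group, sits at the same number as compound 3, but its other ring differs, so it gives no direct guide. Compound 4 is therefore expected to fall between those two cases, at 100 mg/kg with a range of 30 mg/kg to 300 mg/kg, meaning an expected step of a 3.0-fold lower number from compound 3 to compound 4 (0.48 log units; beyond the scatter).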

Compound 4, minimum effective dose: 100 mg/kg
Estimate against measurement, compound 4: no gap at the digits printed, and the stated range covers the measured number.
By their numbers in this assay, from the lowest: compound 2; then compound 4; then compounds 1 and 3 (each within the scatter of the next).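

In this assay, hydrogen in place of methoxy on the aromatic carbon gives a 3.0-fold lower number from compound 3 to compound 4 (0.48 log units; beyond the scatter), while hydrogen in place of methyl gives a 3.3-fold higher number from compound 2 to compound 4 (0.52 log units; beyond the scatter), so with the nitro group held constant, the phenyl of compound 4 ranks between the 2-methoxyphenyl and 4-methylphenyl groups, each step beyond the scatter. The other end of the molecule can now be read as well: nitro in place of bromo gives a 3.0-fold lower number from compound 1 to compound 4 (0.48 log units; beyond the scatter), with the anilino group held constant. No measurement at hand gives a reason for any of these steps.

The compounds shown leave open how an amine, a hydroxy group or a fluorine would read on the anilino ring. They also leave open whether methyl and methoxy would give the same numbers if exchanged for one another on that ring.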